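This account rests on a few compounds, and the source may have more. Where it says the series, first, only, none or still open, it means among the compounds named here.

In a functional assay on cells (Homo sapiens) for cytotoxicity, read by resazurin assay, with a stated time of 72 h (a lower number here means a stronger inhibitor, a higher number a weaker inhibitor), compound 1 `COc1cc(/C=C/C(=O)OCCCCCCO[N+](=O)[O-])ccc1O` gives > 50000 nM, which is a limit and not a number. Compound 2 `O=C(/C=C/c1ccc(OCCCCCO[N+](=O)[O-])c(O)c1)OCCCCCO[N+](=O)[O-]` gives > 50000 nM, also a limit. Compound 3 `COc1cc(/C=C/C(=O)OCCCO[N+](=O)[O-])ccc1OCCCO[N+](=O)[O-]` gives > 50000 nM, again a limit. Compound 1 therefore stands with the other two compounds, at the limit of > 50000 nM in this assay, at which 3 of the 3 values shown sit, and no order among the three can be read.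

Compound 4 `COc1cc(/C=C/C(=O)OCCCCCO[N+](=O)[O-])ccc1O` differs from compound 1 in one place: nitrooxy in place of (nitrooxy)methyl on a saturated chain carbon, five bonds along the chain from an oxygen next to a carbonyl group. In words, nitrooxy stands in place of (nitrooxy)methyl on a saturated chain carbon, five bonds along the chain from an oxygen next to a carbonyl group.

Going by the values given here, the measured compounds offer no step to scale this change against. In this assay no shift beyond the scatter is expected, in either direction. The expected step is a step that the limit leaves unreadable from compound 1 to compound 4, an estimate within the scatter. That expectation rests on compound 1 at > 50000 nM, a limit. For compound 4 the estimated value is 55000 nM, with an expected range from 30000 nM to 100000 nM.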

Compound 4, half-maximal inhibitory concentration: 24900 nM
Compound 4: middle estimate off by 2.2-fold (0.34 log units), on the high side; the whole stated range lies above it.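

In this assay, going by these compounds alone, compound 4 gives 24900 nM, the only value so far that is a number, which gives this chain position a first readable point. Nitrooxy in place of (nitrooxy)methyl amounts to an at least 2.0-fold lower number from compound 1 to compound 4 (0.30 log units; that floor lies within the scatter), so this change cannot yet be called a shift beyond the scatter, and its full size cannot be read. The remaining values give no further reading of the series: the limit of > 50000 nM in this assay, at which 3 of the 4 values shown sit.

Open, from the compounds shown here alone, is whether a carboxylic acid or an amine in place of the nitrooxy group at the chain end, or a chain longer than that of compound 1, would give a number in this assay. Compound 2 and compound 3 differ from compound 4 in more than one place, so they do not show what the second nitrooxy-bearing chain contributes.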